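Heteroaryl exchange at the assay limit

A few compounds are considered here, and "the series" means these few. Any claim that something is new, unique, unknown or untested is made for them only; others in the source may bear on it.

Measured in a functional assay on U-373MG ATCC cells for inhibition, with U373 MG (Homo sapiens) as the target, read by MTT assay, with a stated time of 7 days; on this read-out lower numbers stand for stronger inhibition of growth and higher numbers for weaker inhibition of growth
compound 1 `NC(=O)c1ncn2c(=O)n(Cc3ccsc3)nnc12` gives > 50000 nM as a limit
compound 2 `Cc1noc(Cn2nnc3c(C(N)=O)ncn3c2=O)n1` gives > 50000 nM as a limit

Compound 2 stands at > 50000 nM as a limit and not as a number. Compound 3 `NC(=O)c1ncn2c(=O)n(Cc3c[nH]nn3)nnc12` carries 1H-1,2,3-triazol-4-yl in place of 3-methyl-1,2,4-oxadiazol-5-yl on a saturated chain carbon bound to an aromatic nitrogen on the shared core. Among the measured compounds shown here, the one measured step at this place is a step that the two limits leave unreadable from compound 1 to compound 2 and gives no size to carry over, and the series shows only the limit of > 50000 nM in this assay, at which 2 of the 2 values shown sit, as its evidence. The estimated change is a number no higher from compound 2 to compound 3 (the limit leaves the size open) and no step beyond the scatter is expected in either direction. For compound 3 the expected value is 50000 nM with an estimated range from 25000 nM to 100000 nM in this assay and a reading at the limit is likely.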

Compound 3, concentration for 50% growth inhibition: > 50000 nM
Compound 3 was reported as a limit; the forecaster's own chance of this, stated with the estimate: 85%; the middle value sits exactly at the limit.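

In this assay compound 3 gives > 50000 nM, a limit and not a number, and the steps linking compound 1, compound 2 and compound 3 cannot be read. Going by these compounds, whether any exchange at this place changes growth inhibition stays open.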